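Swapping phenyl for furan-3-yl on a chloro compound

The compounds below may be only part of what the source reports. "The series", "measured", "known", "first", "only" and "open" are said of these compounds alone.

In a functional assay on HCT-116 cells (Homo sapiens), read by sulforhodamine B assay, with a stated time of 5 days (a lower number here means a stronger inhibitor of growth, a higher number a weaker inhibitor of growth), compound 1 `OC[C@H]1O[C@@H](n2cc(F)c3c(-c4ccccc4)ncnc32)[C@H](O)[C@@H]1O` reads > 10000 nM, which is a limit of the assay and not a number. Compound 2 `OC[C@H]1O[C@@H](n2cc(F)c3c(-c4nccs4)ncnc32)[C@H](O)[C@@H]1O` gives 1300 nM. Compound 3 `OC[C@H]1O[C@@H](n2cc(Cl)c3c(-c4ccccc4)ncnc32)[C@H](O)[C@@H]1O` gives 1400 nM, within the usual scatter of the value for compound 2.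

Compound 4 `OC[C@H]1O[C@@H](n2cc(Cl)c3c(-c4ccoc4)ncnc32)[C@H](O)[C@@H]1O` keeps the chloro group of compound 3 and changes one other group, with furan-3-yl in place of phenyl on an aromatic carbon.

The closest guide is an at least 7.6-fold lower number from compound 1 to compound 2 (0.88 log units; beyond the scatter), where 1,3-thiazol-2-yl replaces phenyl while fluoro stays. The other measured change, an at least 7.1-fold lower number from compound 1 to compound 3 (0.85 log units; beyond the scatter), swaps fluoro for chloro and shows that the halogen matters as well, but it leaves the phenyl group untouched. From the compounds shown here alone, both sizes start from a limit, so the true steps are unknown. The guide also involves a different ring on a different halogen, so it transfers only loosely.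

A lower number is still expected, with an estimated change of a 9.3-fold lower number from compound 3 to compound 4 (0.97 log units; beyond the scatter). For compound 4 the estimate is 150 nM, with an expected range from 30 nM to 800 nM.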

Compound 4, concentration for 50% growth inhibition: 2000 nM
Compound 4: middle estimate off by 13-fold (1.12 log units), on the low side; the whole stated range lies below it.
By their numbers in this assay, from the lowest: compounds 2, 3 and 4 (each within the scatter of the next). At a limit, above all of these: compound 1.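

In this assay the change on the chloro compound gives a 1.4-fold higher number from compound 3 to compound 4 (0.15 log units; within the scatter) and so lies within the scatter: at this position, next to the ring nitrogen, furan-3-yl and phenyl cannot be told apart, even though furan-3-yl brings a five-membered ring and a hydrogen-bond acceptor. The earlier ring swap on the fluoro compound, which starts from a limit of the assay, gave an at least 7.6-fold lower number from compound 1 to compound 2 (0.88 log units; beyond the scatter) with 1,3-thiazol-2-yl as the new group, so replacing phenyl with a five-membered aromatic ring does not lower the number in every case shown. Nothing shown here bears on the reason for this result.

From the compounds shown here alone, it remains open how 1,3-thiazol-2-yl would read on the chloro compound, or furan-3-yl on the fluoro compound. Also open, going by these compounds, is how a group without a ring, such as an amine or a methoxy group, would read at this position.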